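A few compounds are considered here, and "the series" means these few. Any claim that something is new, unique, unknown or untested is made for them only; others in the source may bear on it.

Measured so far:
- compound 1 `COc1ccc(-c2cc(C(=O)/C=C/c3cccc(OC)c3OC)ccc2N)cc1OC` gives 6600 nM
- compound 2 `COc1ccc(/C=C/C(=O)c2ccc(N)c(-c3ccc(OC)c(OC)c3)c2)c(OC)c1` gives 8340 nM

Among the measured compounds shown here, in a functional assay on CNE-2 cells (Homo sapiens) for cytotoxicity, read by sulforhodamine B assay, with a stated time of 48 h (on this read-out lower numbers stand for stronger inhibition and higher numbers for weaker inhibition), compound 1 gives 6600 nM and compound 2 gives 8340 nM so compound 1 stands level with the only other number, within the scatter of it.

Compared with compound 1, the unmeasured compound 3 `COc1cccc(/C=C/C(=O)c2ccc(N)c(-c3ccc(F)cc3)c2)c1OC` carries 4-fluorophenyl in place of 3,4-dimethoxyphenyl on an aromatic carbon ortho to an amino group 4-fluorophenyl in place of 3,4-dimethoxyphenyl on an aromatic carbon and keeps everything else.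

For the measured compounds named here, the only measured step of a 1.3-fold higher number from compound 1 to compound 2 (0.10 log units; within the scatter) puts 2,4-dimethoxyphenyl in place of 2,3-dimethoxyphenyl. Going by the values given here, that is a different place in the molecule, so it gives only weak guidance here, and no measured step touches the 3,4-dimethoxyphenyl group.

The expected step of a 1.1-fold higher number from compound 1 to compound 3 (0.06 log units; within the scatter) in this assay is therefore none beyond the scatter, with no direction favoured and wide uncertainty.

The expected value for compound 3 is 7500 nM (estimated range 2500 nM to 22000 nM).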

Compound 3, half-maximal inhibitory concentration: 11300 nM
Compound 3: middle estimate off by 1.5-fold (0.18 log units), on the low side, and the stated range covers the measured number.
By their numbers in this assay, from the lowest: compounds 1, 2 and 3 (each within the scatter of the next).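

In this assay, the first change measured at this position, 4-fluorophenyl in place of 3,4-dimethoxyphenyl on an aromatic carbon ortho to an amino group, gives a 1.7-fold higher number from compound 1 to compound 3 (0.23 log units; within the scatter). So the group here can go from 10 heavy atoms to 7 and from 2 hydrogen-bond acceptors to 0 while the two numbers stay within the usual scatter of each other, and this single pair shows no clear need for the methoxy groups at this place. Nothing available explains this result.

As far as these compounds go, whether the fluorine itself matters remains open, since a plain phenyl group on the same carbon would be needed to separate it from the loss of the methoxy groups. From the compounds shown here alone, how a group of a different kind, such as an amine or a carboxylic acid on that ring, would read in this assay also remains open.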